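A few compounds are considered here, and "the series" means these few. Any claim that something is new, unique, unknown or untested is made for them only; others in the source may bear on it.

Measured so far:
compound 1, `COc1ccc(-n2c(S)nnc2-c2cc(OC)c(OC)c(OC)c2)cc1` — in a functional assay on HT-29 cells (Homo sapiens) for inhibition, read by MTT assay, with a stated time of 48 h (on this read-out lower numbers stand for stronger inhibition and higher numbers for weaker inhibition), compound 1 gives > 60000 nM, a limit of the assay and not a number.
compound 2, `COc1ccc(-n2c(SCC(=O)c3ccccc3)nnc2-c2cc(OC)c(OC)c(OC)c2)cc1` — in this assay compound 2 gives > 60000 nM, again only a limit.
compound 3, `COc1ccc(-n2c(SCC(=O)c3ccc(F)cc3)nnc2-c2cc(OC)c(OC)c(OC)c2)cc1` — in this assay compound 3 gives 42500 nM.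

Among the measured compounds shown here, compound 3 therefore stands as the only compound with a number; the other two values sit at the limit of > 60000 nM in this assay, at which 2 of the 3 values shown sit. The steps that reach it are an at least 1.4-fold lower number from compound 1 to compound 3 (0.14 log units; that floor lies within the scatter) and an at least 1.4-fold lower number from compound 2 to compound 3 (0.14 log units; that floor lies within the scatter), both floored by the limit and within the scatter; a step that the two limits leave unreadable from compound 1 to compound 2.

Compound 4, `COc1ccc(-n2c(SCC(=O)C3CC3)nnc2-c2cc(OC)c(OC)c(OC)c2)cc1`, differs from compound 3 in one place: cyclopropyl in place of 4-fluorophenyl on a carbonyl carbon. For the measured compounds named here, no measured step covers a cyclopropyl on the carbonyl carbon. Going by the values given here, the only step that bears on the change is an at least 1.4-fold lower number from compound 2 to compound 3 (0.14 log units; that floor lies within the scatter), since the fluoro that entered there leaves again here, together with the ring that carried it. The expectation is thus a number no lower than that of compound 3 in this assay, most likely drifting back to the limit.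

Compound 4 is estimated at 65000 nM (range 30000 nM to 150000 nM), an expected step of a 1.5-fold higher number from compound 3 to compound 4 (0.18 log units; within the scatter).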

Compound 4, half-maximal inhibitory concentration: > 60000 nM
Compound 4 gave a limit, no number; the forecaster's own chance of this, stated with the estimate: 55%; the middle value lies beyond the limit too.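

In this assay, the position on the carbonyl carbon now carries a small non-aromatic ring as well as aromatic ones, and cyclopropyl in place of 4-fluorophenyl gives an at least 1.4-fold higher number from compound 3 to compound 4 (0.14 log units; that floor lies within the scatter), a floor that lies within the scatter. The steps joining compound 4 to compound 1 and to compound 2 cannot be read, as each has a limit at both ends. The series now gathers at a single limit, with compound 3 the only compound holding a number: the limit of > 60000 nM in this assay, at which 3 of the 4 values shown sit.

As far as these compounds go, whether an amine or a longer chain on the carbonyl carbon would give a number clear of that limit stays open. With a single number in the series, the fluoro of compound 3 also cannot yet be told apart from the scatter.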